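Imidazoline ethers: five-membered heteroaryl swap

The compounds below may be only part of what the source reports. "The series", "measured", "known", "first", "only" and "open" are said of these compounds alone.

Measured so far:
compound 1 `Cc1cccc(-c2ccccc2OCC2=NCCN2)n1`: 126 nM
compound 2 `c1csc(-c2ccccc2OCC2=NCCN2)c1`: 1 nM

In a functional assay for activation of Alpha-1A adrenergic receptor (Homo sapiens), read by calcium flux (on this read-out lower numbers stand for an effect already at smaller amounts and higher numbers for an effect only at larger amounts of compound), compound 2 gives the lowest of the two numbers; compound 1 gives a higher number, and that gap lies beyond the scatter. No step between two compounds that differ in a single place has been recorded, so the pair compound 1 and compound 2 shows only what its two values show, and no structural cause for the gap can be read off.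

Compound 3 `Cc1ccoc1-c1ccccc1OCC1=NCCN1` is the next point. It differs from compound 2 by 3-methylfuran-2-yl in place of thiophen-2-yl on an aromatic carbon. Both the leaving and the entering group are five-membered aromatic rings carrying one hetero atom, as counted, and the entering group carries one more heavy atom.

For the step from compound 2 to compound 3 in this assay a small move toward a higher number is expected, possibly none beyond the scatter. Compound 3 is therefore estimated at 3 nM, within 0.7 nM to 15 nM. The estimated step of a 3.0-fold higher number from compound 2 to compound 3 (0.48 log units; beyond the scatter) is expected to stay close to the scatter.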

Compound 3, half-maximal effective concentration: 3.16 nM
Beside the measured number, compound 3's estimate is 1.1-fold (0.02 log units) below it; the measured number falls inside the stated range.
By their numbers in this assay, from the lowest: compound 2; then compound 3; then compound 1.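

In this assay, going by these compounds alone, 3-methylfuran-2-yl in place of thiophen-2-yl on an aromatic carbon gives a 3.2-fold higher number from compound 2 to compound 3 (0.50 log units; beyond the scatter), the first step with a single point of difference, and it is modest although beyond the scatter. The step keeps the five-membered aromatic ring with one hetero atom, while oxygen replaces sulfur and the entering group carries one more heavy atom, so compound 3, at 3.16 nM, shows that this position accepts a combined change of this kind with only a modest rise in the number. No measurement at hand bears on the reason for the step.

The ring atom and the methyl group change together here, so their separate contributions cannot be read from this step; an unsubstituted furan ring and a methylthiophene ring would be the two compounds to separate them. As far as these compounds go, how this position responds to groups of a different kind, such as an aminomethyl group or a carboxylic acid on the five-membered ring, remains open.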